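Methyl-Oxadiazole in Place of Dimethylcarbamoyl on the Shared Core

This account rests on a few compounds, and the source may have more. Where it says the series, first, only, none or still open, it means among the compounds named here.

Measured compounds:
compound 1 `Cc1nc(C(=O)NO)c(N)c2c1C(=O)N(Cc1ccccc1)C2=O`: "not determined" (no result reported)
compound 2 `Cc1nc(C(=O)N(C)C)c(N)c2c1C(=O)N(Cc1ccccc1)C2=O`: > 100000 nM

Compound 1 `Cc1nc(C(=O)NO)c(N)c2c1C(=O)N(Cc1ccccc1)C2=O` carries a hydroxamic acid on the shared core; in an ADME assay on Vero cells (Chlorocebus sabaeus) for cytotoxicity, read by MTT assay (on this read-out higher numbers stand for weaker inhibition and lower numbers for stronger inhibition), compound 1 has no result, its entry reading "not determined" (no result reported). Compound 2 `Cc1nc(C(=O)N(C)C)c(N)c2c1C(=O)N(Cc1ccccc1)C2=O` carries a dimethylcarbamoyl group at the same position. In this assay compound 2 gives > 100000 nM, which is a limit of the assay and not a number. Compound 2 therefore stands at the edge of what the numbers shown can tell: the limit of > 100000 nM in this assay, at which 1 of the 2 values shown sits.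

Compound 3 `Cc1noc(-c2nc(C)c3c(c2N)C(=O)N(Cc2ccccc2)C3=O)n1` has not yet been measured in this assay. Its difference from compound 2 is 3-methyl-1,2,4-oxadiazol-5-yl in place of dimethylcarbamoyl on an aromatic carbon. Going by the values given here, no step between two measured compounds exists here, so the numbers give no guide to how this assay answers a change of this kind. The step of a number no higher from compound 2 to compound 3 (the limit leaves the size open) is expected to be none beyond the usual scatter, with compound 3 most likely again reported only as a limit. Compound 3 is expected to give 100000 nM, within a range from 30000 nM to 300000 nM.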

Compound 3, half-maximal inhibitory concentration: > 100000 nM
Compound 3 ended at the assay's limit; the forecaster's own chance of this, stated with the estimate: 75%; the middle value lies on the limit itself.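

In this assay compound 3 gives > 100000 nM, which is a limit of the assay and not a number. Going by these compounds alone, compound 2 also stands at a limit, so no step from compound 2 to compound 3 can be read. The compounds shown leave open whether 3-methyl-1,2,4-oxadiazol-5-yl in place of dimethylcarbamoyl changes this read-out at all.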